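The compounds below may be only part of what the source reports. "The series", "measured", "known", "first", "only" and "open" are said of these compounds alone.

Measured in a functional assay on DU-145 cells (Homo sapiens) for inhibition, read by MTT assay, with a stated time of 72 h; a lower number here means a stronger inhibitor, a higher number a weaker inhibitor:
- compound 1 `O=C1C=C(N2CCN(c3ccc(Cl)cc3)CC2)C(=O)c2ccccc21`: 29500 nM
- compound 2 `O=C1C=C(N2CCN(c3ccccc3)CC2)C(=O)c2ccccc21`: 9900 nM
- compound 3 `O=C1C=C(N2CCN(c3cccc(Cl)c3)CC2)C(=O)c2ccccc21`: 8300 nM

With the unsubstituted phenyl group, compound 2 gives 9900 nM. It cannot be told apart from the 3-chlorophenyl analogue, with a 1.2-fold lower number from compound 2 to compound 3 (0.08 log units; within the scatter). The 4-chlorophenyl analogue stands clear of both, with a 3.0-fold lower number from compound 1 to compound 2 (0.47 log units; beyond the scatter) and a 3.6-fold lower number from compound 1 to compound 3 (0.55 log units; beyond the scatter).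

Compound 4 `O=C1C(N2CCN(c3ccccc3)CC2)=CC(=O)c2c(O)cccc21` keeps the phenyl group of compound 2 and changes the shared core instead: hydroxy in place of hydrogen on an aromatic carbon. Within the data shown here, no measured step touches that ring, so the chloro steps bear on it only loosely. They show that exchanging one substituent moved the number modestly at most in this small set, and they give no direction for a hydroxy group. A modest step toward a lower number is therefore expected in this assay, though with little support and a wide margin.

The expected change is a 2.0-fold lower number from compound 2 to compound 4 (0.30 log units; within the scatter).

For compound 4 the estimated value is 5000 nM, within an expected range of 1500 nM to 15000 nM.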

Compound 4, half-maximal inhibitory concentration: 15200 nM
Compound 4: middle estimate off by 3.0-fold (0.48 log units), on the low side; measured number above the stated range.
By their numbers in this assay, from the lowest: compounds 3, 2, 4 and 1 (each within the scatter of the next, the first and the last beyond it).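

Putting a hydroxy group on an aromatic carbon of the shared core, ortho to a fused ring and meta to a fused ring, gives a result that cannot be separated from the parent in this assay, with a 1.5-fold higher number from compound 2 to compound 4 (0.19 log units; within the scatter). Among these compounds, all the earlier steps concerned the phenyl group on the amine nitrogen, so this is the first reading of a change on the core, and at this position, swapping hydrogen for hydroxy does not move the number beyond the scatter. Nothing measured here bears on why the number stays within the scatter.

The compounds shown leave open how a methoxy group or an amine would read at this same position. They also leave open whether the hydroxy group would give a similar reading when paired with the 4-chlorophenyl group of compound 1.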